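Removing the Fluoro Group from Compound 1

This account rests on a few compounds, and the source may have more. Where it says the series, first, only, none or still open, it means among the compounds named here.

Measured so far:
compound 1, `Cc1ccc(S(=O)(=O)N[C@@H](CC(=O)NC(C)(C)C)C(=O)NCCNC(=O)c2c(O)cccc2F)cc1`: > 11100 nM
compound 2, `Cc1ccc(S(=O)(=O)N[C@@H](CC(=O)NC(C)(C)C)C(=O)NCCNS(=O)(=O)c2ccccc2)cc1`: > 11100 nM
compound 3, `Cc1ccc(S(=O)(=O)N[C@@H](CC(=O)NC(C)(C)C)C(=O)NCCNC(=O)c2cc(C)ccn2)cc1`: > 11100 nM

In an ADME assay on Karpas-1106P cells (Homo sapiens) for cytotoxicity (a lower number here means that less compound is needed, a higher number that more compound is needed for the effect), compound 1 gives > 11100 nM, which is a limit of the assay rather than a number. Compound 2 in this assay gives > 11100 nM, also a limit. Compound 3 in this assay gives > 11100 nM, again a limit. The three steps among them, a step that the two limits leave unreadable from compound 1 to compound 2, a step that the two limits leave unreadable from compound 1 to compound 3 and a step that the two limits leave unreadable from compound 2 to compound 3, therefore cannot be read, since (the limit of > 11100 nM in this assay, at which 3 of the 3 values shown sit).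

Compound 4, `Cc1ccc(S(=O)(=O)N[C@@H](CC(=O)NC(C)(C)C)C(=O)NCCNC(=O)c2ccccc2O)cc1`, is compound 1 with one change: hydrogen in place of fluoro on an aromatic carbon. Among the compounds with values here, no measured step concerns this change itself, and the three steps that exist are all unreadable, so nothing in the numbers points to a gain or a loss. Compounds 1, 2 and 3 all sit at the limit, so the account expects compound 4 to sit at the limit as well, and estimates its value in this assay at 20000 nM, in a range from 8000 nM to 60000 nM. That estimate means a step that the limit leaves unreadable from compound 1 to compound 4, which is expected to be no step beyond the scatter.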

Compound 4, half-maximal effective concentration: > 11100 nM
Compound 4: no number, only a limit; the forecaster's own chance of this, stated with the estimate: 85%; the middle value lies beyond the limit too.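

In this assay compound 4 gives > 11100 nM, which is a limit and not a number. Its steps to compound 1, compound 2 and compound 3 therefore cannot be read, because all four compounds end at the same point: the limit of > 11100 nM in this assay, at which 4 of the 4 values shown sit.

The compounds shown leave open whether hydrogen in place of fluoro, or any other change among them, alters the concentration needed for the effect.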